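Aryl variation at the bicyclic core: naphthyl to tert-butylphenyl

A few compounds are considered here, and "the series" means these few. Any claim that something is new, unique, unknown or untested is made for them only; others in the source may bear on it.

Three compounds of this series carry the same side chain and differ only in the group attached to an aromatic carbon of the shared core. In an ADME assay on HepG2 cells (Homo sapiens) for cytotoxicity, read by luminescence, CellTiter-Glo and ATP content, with a stated time of 72 h (on this read-out higher numbers stand for an effect only at larger amounts of compound and lower numbers for an effect already at smaller amounts), compound 1 `COc1ccc(F)cc1CNCCCNc1ccnc2cc(Cc3cc(C)cc(C)c3)ccc12` gives 940 nM. Compound 2 `COc1ccc(F)cc1CNCCCNc1ccnc2cc(-c3ccc(F)cc3)ccc12` gives 770 nM in this assay, and the step of a 1.2-fold lower number from compound 1 to compound 2 (0.09 log units; within the scatter) is no change to speak of. Compound 3 `COc1ccc(F)cc1CNCCCNc1ccnc2cc(-c3cccc4ccccc34)ccc12` gives 16000 nM in this assay, the highest of the three numbers, set apart by a 17-fold higher number from compound 1 to compound 3 (1.23 log units; beyond the scatter) and by a 21-fold higher number from compound 2 to compound 3 (1.32 log units; beyond the scatter).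

The next compound, compound 4 `COc1ccc(F)cc1CNCCCNc1ccnc2cc(-c3ccc(C(C)(C)C)cc3)ccc12`, has not yet been measured in this assay. It differs from compound 3 as follows: 4-(tert-butyl)phenyl in place of naphthalen-1-yl on an aromatic carbon. Both steps that bear on this change, a 17-fold higher number from compound 1 to compound 3 (1.23 log units; beyond the scatter) and a 21-fold higher number from compound 2 to compound 3 (1.32 log units; beyond the scatter), show that a group of two six-membered aromatic rings stands out from the groups of one such ring. Compound 4 returns to a group of one six-membered aromatic ring, so a step in this assay back toward the numbers of compound 1 and compound 2 is expected, with a direction of lower numbers; the expected step is an 8.0-fold lower number from compound 3 to compound 4 (0.90 log units; beyond the scatter). For compound 4 the estimate in this assay is 2000 nM, with a range from 600 nM to 7000 nM.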

Compound 4, half-maximal effective concentration: 620 nM
The estimate for compound 4 lay 3.2-fold (0.51 log units) above the measured number; low and high end bracket the measured number.
By their numbers in this assay, from the lowest: compounds 4, 2 and 1 (each within the scatter of the next); then compound 3.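

In this assay, the exchange of naphthalen-1-yl for 4-(tert-butyl)phenyl leaves the group at 10 heavy atoms, all carbon, yet gives a 26-fold lower number from compound 3 to compound 4 (1.41 log units; beyond the scatter), so among these two groups the heavy-atom count does not track the number, while the count of six-membered aromatic rings does differ. On the phenyl group, tert-butyl in place of fluoro gives a 1.2-fold lower number from compound 2 to compound 4 (0.09 log units; within the scatter), and the comparison with the 3,5-dimethylbenzyl group gives a 1.5-fold lower number from compound 1 to compound 4 (0.18 log units; within the scatter), so compounds 1, 2 and 4 form one group within the scatter despite their different substituents, and compound 3 alone stands apart. No measurement at hand gives a reason for the separation of compound 3 from the others.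

With a single group of two six-membered aromatic rings, the compounds shown leave open whether the high number belongs to such groups in general or to naphthalen-1-yl alone. They also leave open how the number responds when a carboxylic acid or a primary amine takes the place of tert-butyl on the phenyl group.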